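This account rests on a few compounds, and the source may have more. Where it says the series, first, only, none or still open, it means among the compounds named here.

Compound 1 `Clc1ccc(-c2cc(-c3cccnc3)nc(-c3ccsc3)c2)o1` and compound 2 `Cc1ccc(-c2cc(-c3ccc(Cl)o3)cc(-c3cccs3)n2)cc1` share a core that carries three aromatic groups, and both were tested in a functional assay on DU-145 cells (Homo sapiens) for cytotoxicity, in the presence of a further agent that is not named here; a higher number here means a weaker inhibitor, a lower number a stronger inhibitor. In that test compound 1 gives 21600 nM, while compound 2 gives 19300 nM. Compound 1 thus stands at the top of the pair on the numbers, but the gap to compound 2 lies within the usual scatter, so the two cannot be told apart. The next compound, compound 3 `Cc1ccccc1-c1cc(-c2ccc(Cl)o2)cc(-c2ccsc2)n1`, differs from compound 1 in one place: 2-methylphenyl in place of pyridin-3-yl on an aromatic carbon. For the measured compounds named here, no pair of measured compounds shows the size of such a step, and nothing in the two numbers points in either direction, so the step from compound 1 to compound 3 is expected to stay within the scatter, at a 1.1-fold lower number from compound 1 to compound 3 (0.03 log units; within the scatter). Compound 3 is therefore estimated to give 20000 nM in this assay, within a range from 8000 nM to 50000 nM.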

Compound 3, half-maximal inhibitory concentration: 24800 nM
Estimate against measurement, compound 3: 1.2-fold (0.09 log units) below; the range from low to high includes it.
By their numbers in this assay, from the lowest: compounds 2, 1 and 3 (each within the scatter of the next).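

In this assay, for the compounds shown here, the first step that can be read at this place, on an aromatic carbon next to the ring nitrogen, gives a 1.1-fold higher number from compound 1 to compound 3 (0.06 log units; within the scatter). The hydrogen-bond acceptor of pyridin-3-yl is absent from 2-methylphenyl, yet the step stays within the scatter, so this exchange of one uncharged six-membered aromatic ring for another does not separate the two compounds in this test. No supporting measurement bears on this result.

The compounds shown leave open whether any group at this place can move the number beyond the scatter. Both groups seen here are uncharged six-membered aromatic rings, so a carboxylic acid, an aminomethyl group or a longer alkyl chain on the same carbon remains an open case.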